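The source may report more compounds than this note shows. Statements on the series, on what has been measured and on what is new or still open speak of the compounds shown alone.

Of the compounds shown here, three built on a shared core have so far been measured in a physicochemical assay for lipophilicity, read by HPLC; on this read-out higher numbers stand for higher lipophilicity and lower numbers for lower lipophilicity. Compound 1 `COc1ccc(NC[C@H](O)COc2ccc(N3C[C@H](CNC(C)=O)OC3=O)cc2F)cc1` gives 0.95, compound 2 `COc1ccc(NC[C@@H](O)COc2ccc(N3C[C@H](CNC(C)=O)OC3=O)cc2F)cc1` gives 1.15, and compound 3 `CC(=O)NC[C@H]1CN(c2ccc(OC[C@@H](O)CNc3ccccc3)c(F)c2)C(=O)O1` gives 1.42. For the measured compounds named here, of the steps among them, the one that swaps hydrogen in place of methoxy on an aromatic carbon reads as a number 0.47 log units higher from compound 1 to compound 3 (beyond the scatter), whereas the values of compound 2 and compound 3 lie within the usual scatter of each other, so no order between those two can be read from the numbers.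

Compound 4 `CC(=O)NC[C@H]1CN(c2ccc(OC[C@H](O)CNc3ccccc3)c(F)c2)C(=O)O1` has not yet been measured. How it differs from compound 3 is this: the two compounds have the same atoms and bonds and differ only in configuration as drawn: 1 of 2 stereo elements differ; a stereocentre at a saturated chain carbon is drawn S in compound 3 and R in compound 4. Going by the values given here, one measured step bears directly on such a change. It rests on (the fact that compounds 1 and 2 differ only in the configuration as drawn), the same kind of inversion at a saturated chain carbon, and it gave a number 0.20 log units higher from compound 1 to compound 2 (within the scatter). On that evidence the step in this assay is expected to be small, if anything a slight rise, and not beyond the scatter, so that the estimated step is a number 0.18 log units higher from compound 3 to compound 4 (within the scatter). Compound 4 is therefore estimated at 1.6, with a range from 1.35 to 1.85.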

Compound 4, partition coefficient: 0.59
For compound 4 the middle estimate is 1.01 log units above the measured one; the whole stated range lies above it.
By their numbers in this assay, from the lowest: compound 4; then compounds 1, 2 and 3 (each within the scatter of the next, the first and the last beyond it).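

With hydrogen on the aromatic carbon, inverting the stereocentre at the saturated chain carbon from S to R gives a number 0.83 log units lower from compound 3 to compound 4 (beyond the scatter) in this assay, whereas with methoxy on that carbon the same inversion gave a number 0.20 log units higher from compound 1 to compound 2 (within the scatter), so the size of this change does not carry over from one pair to the other. The swap of hydrogen in place of methoxy also changes direction with the configuration, giving a number 0.47 log units higher from compound 1 to compound 3 (beyond the scatter) with the chain carbon drawn S but a number 0.56 log units lower from compound 2 to compound 4 (beyond the scatter) with it drawn R. The shift within the hydrogen pair can be tied to the stereocentre alone, since nothing else separates those two structures: the fact that compounds 3 and 4 differ only in the configuration as drawn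

Each of these comparisons rests on a single pair, so the compounds shown cannot tell whether the dependence on configuration is general or particular to these two substituents. Nor do they show whether another group on that aromatic carbon, such as chloro, methyl or a carboxylic acid, would leave the inversion as small as with methoxy or make it as large as with hydrogen.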